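A Methoxy Group Added to a Level Cytotoxicity Series

The compounds below may be only part of what the source reports. "The series", "measured", "known", "first", "only" and "open" are said of these compounds alone.

Of the compounds shown here, three sharing a common core have been measured in a functional assay on HL-60 cells (Homo sapiens) for cytotoxicity, with a stated time of 24 h; a lower number here means that less compound is tolerated, a higher number that more compound is tolerated. In this assay compound 1 (`O=C1/C(=C/c2ccc(F)cc2)CCC/C1=C\c1ccccc1[N+](=O)[O-]`) gives 3000 nM. Compound 2 (`COc1cc(/C=C2\CCC/C(=C\c3ccccc3[N+](=O)[O-])C2=O)cc(OC)c1OC`) gives 3000 nM, and compound 3 (`O=C1/C(=C/c2ccccc2)CCC/C1=C\c1cccc([N+](=O)[O-])c1`) gives 3000 nM. Compound 3 therefore stands level with the other two, with nothing separating the three values.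

Compound 4 (`COc1ccc(/C=C2\CCC/C(=C\c3cccc([N+](=O)[O-])c3)C2=O)cc1`) departs from compound 3 in a single place (methoxy in place of hydrogen on an aromatic carbon). It has methoxy in place of hydrogen on an aromatic carbon of a six-membered aromatic ring of carbon only, para to a large group, so that phenyl becomes 4-methoxyphenyl. Among the compounds with values here, no direct measurement of this change is available, since no two measured compounds differ in just one place. The closest guide is compound 2, which also carries methoxy groups and gives 3000 nM. On that basis, no step beyond the usual scatter is expected in this assay, in either direction. The expected change is no change at the digits printed from compound 3 to compound 4 (within the scatter). For compound 4 the estimated value is 3000 nM, with an expected range from 1300 nM to 7000 nM.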

Compound 4, half-maximal cytotoxic concentration: 7200 nM
Compound 4: the middle estimate sits 2.4-fold (0.38 log units) below what was measured; measured number above the stated range.
By their numbers in this assay, from the lowest: compounds 1, 2 and 3 (each within the scatter of the next); then compound 4.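

Methoxy in place of hydrogen on an aromatic carbon, para to a large group, turns phenyl into 4-methoxyphenyl and gives, in this assay, a 2.4-fold higher number from compound 3 to compound 4 (0.38 log units; beyond the scatter). Within the data shown here, this is the first single-place step, and a modest one. Among these compounds, the earlier values stood level and gave no step to read, so this result is the first sign that a change at this position can register in this read-out, here in the direction of more compound being tolerated. No evidence is at hand that bears on this result.

As far as these compounds go, whether the step belongs to methoxy in particular or would also follow another group at this position, such as hydroxy, chlorine or dimethylamino, remains open. The compounds shown also leave open whether methoxy would give a similar step at another place on this ring, or whether it would do so on a compound that differs elsewhere from compound 3.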